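The compounds below may be only part of what the source reports. "The series", "measured", "known", "first", "only" and "open" are said of these compounds alone.

Compound 3 `CC(=O)OC[C@H]1O[C@@H](n2cc(CN3C(=O)/C(=C\c4ccco4)c4ccccc43)nn2)[C@H](OC(C)=O)[C@@H](OC(C)=O)[C@@H]1OC(C)=O` gives 38200 nM in a functional assay on MCF7 cells (Homo sapiens) for cytotoxicity, read by sulforhodamine B assay, with a stated time of 48 h (on this read-out lower numbers stand for stronger inhibition and higher numbers for weaker inhibition), the higher of the two numbers available, though its gap to compound 2 lies within the scatter. Compound 2 `CC(=O)OC[C@H]1O[C@@H](n2cc(CN3C(=O)/C(=C/c4ccc(N(C)C)cc4)c4ccccc43)nn2)[C@H](OC(C)=O)[C@@H](OC(C)=O)[C@@H]1OC(C)=O` gives 25200 nM in this assay. Compound 1 `CC(=O)OC[C@H]1O[C@@H](n2cc(CN3C(=O)/C(=C/c4ccc(C)cc4)c4ccccc43)nn2)[C@H](OC(C)=O)[C@@H](OC(C)=O)[C@@H]1OC(C)=O` reaches only the limit > 100000 nM in this assay. Among the compounds with values here, the only measured step, an at least 3.9-fold lower number from compound 1 to compound 2 (0.59 log units; beyond the scatter), concerns a substituent on an aromatic carbon and does not touch the geometry of the exocyclic double bond. Compound 4 `CC(=O)OC[C@H]1O[C@@H](n2cc(CN3C(=O)/C(=C/c4ccco4)c4ccccc43)nn2)[C@H](OC(C)=O)[C@@H](OC(C)=O)[C@@H]1OC(C)=O` differs from compound 3 in that (the two compounds have the same atoms and bonds and differ only in configuration as drawn: 1 of 6 stereo elements differ; a double bond is drawn Z in compound 3 and E in compound 4). Within the data shown here, no measured step speaks to such a change, so the expected step, a 1.0-fold lower number from compound 3 to compound 4 (0.00 log units; within the scatter), is none beyond the scatter. Compound 4 is therefore estimated at 38000 nM in this assay, within a range from 10000 nM to 150000 nM.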

Compound 4, half-maximal inhibitory concentration: 29100 nM
Beside the measured number, compound 4's estimate is 1.3-fold (0.12 log units) above it, within the range that was stated.
By their numbers in this assay, from the lowest: compounds 2, 4 and 3 (each within the scatter of the next). At a limit, above all of these: compound 1.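

In this assay, drawing the double bond E rather than Z gives a 1.3-fold lower number from compound 3 to compound 4 (0.12 log units; within the scatter) and so this change of configuration alone does not separate the two furan-2-yl compounds. At the same position, furan-2-yl in place of 4-(dimethylamino)phenyl gives a 1.2-fold higher number from compound 2 to compound 4 (0.06 log units; within the scatter) and does not separate those two compounds either. Furan-2-yl in place of 4-methylphenyl gives an at least 3.4-fold lower number from compound 1 to compound 4 (0.53 log units; beyond the scatter) but this step starts from a limit for compound 1: the limit of > 100000 nM in this assay, at which 1 of the 4 values shown sits.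

The compounds shown leave open whether the Z and E forms stay this close with 4-methylphenyl or 4-(dimethylamino)phenyl on the double bond. They also leave open what a thiophen-2-yl or pyridin-3-yl group would give at this position.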